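Swapping a Para Substituent on a Thioether-Linked Anilide

The source may hold more compounds than are shown below. What is called first, only, known or untested is meant among the compounds shown, and "the series" means these compounds.

Compound 1 `Nc1ccccc1NC(=O)/C=C/c1ccc(CSc2ccc(F)cc2)cc1` is the weaker of the two measured compounds in this set. In a functional assay on HCT-116 cells (Homo sapiens) for inhibition, read by CCK-8 assay, with a stated time of 72 h, tested at 8 uM (a lower number here means less inhibition of growth, a higher number more inhibition of growth at the concentration tested), compound 1 gives 20.2%, the lowest of the two numbers recorded, while compound 2 `Cc1ccc(SCc2ccc(C(=O)Nc3ccccc3N)cc2)cc1` in this assay gives 84%, a number that lies beyond the usual scatter above that of compound 1. Within the data shown here, no single-place step connects these two, so the gap between them is noted only as what the values show.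

Compound 3 `CC(C)(C)c1ccc(SCc2ccc(/C=C/C(=O)Nc3ccccc3N)cc2)cc1` is not yet measured. Compared with compound 1 it differs in one place: tert-butyl in place of fluoro on an aromatic carbon. Among the measured compounds shown here, with no measured step of this kind available, the direction and size of the change can only be expected. Compound 3 is expected to show a moderate rise over compound 1, giving an estimated a number 21.8 percentage points higher from compound 1 to compound 3 (beyond the scatter) in this assay. The estimated value for compound 3 is 42%, with a range from 15% to 70%.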

Compound 3, percent growth inhibition at one concentration: 39%
Compound 3: middle estimate off by 3 percentage points, on the high side; the measured number falls inside the stated range.
By their numbers in this assay, from the lowest: compound 1; then compound 3; then compound 2.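

In this assay, among these compounds, the change from 4-fluorophenyl to 4-(tert-butyl)phenyl gives a number 18.8 percentage points higher from compound 1 to compound 3 (beyond the scatter), the first step in this set that can be read at a single place. It shows that this position, on an aromatic carbon para to a large group, can carry a group of four heavy atoms in place of a single one with no loss of growth inhibition at the concentration tested; the number goes up instead. Nothing at hand bears on what lies behind this rise.

The compounds shown leave open how an amine or a carboxylic acid would read at this same position, and so whether the rise follows size or is particular to tert-butyl. They also leave open whether the same swap would go the same way on the core of compound 2.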